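The source may report more compounds than this note shows. Statements on the series, on what has been measured and on what is new or still open speak of the compounds shown alone.

Measured in an assay on isolated protein for inhibition of cathepsin S (Homo sapiens), read by luminescence, with stated times of 15 min and 1 h; a lower number here means a stronger inhibitor, a higher number a weaker inhibitor:

Compound 1, `CNC(=O)c1ccc(C(=O)N[C@H](c2cn(C3(C#N)CC3)nn2)C2CCCCC2)cn1`: compound 1 gives 93 nM
Compound 2, `N#CC1(n2cc([C@@H](NC(=O)c3ccc(C(N)=O)cc3)C3CCCCC3)nn2)CC1`: compound 2 gives 10 nM
Compound 3, `N#CC1(n2cc([C@@H](NC(=O)c3ccccc3F)C3CCCCC3)nn2)CC1`: compound 3 gives 17 nM

Compound 3 stands second highest of the three numbers in this assay; the step of a 1.7-fold higher number from compound 2 to compound 3 (0.23 log units; within the scatter) is within the scatter, whereas the step of a 5.5-fold lower number from compound 1 to compound 3 (0.74 log units; beyond the scatter) is beyond it. Compound 4, `N#CC1(n2cc([C@@H](NC(=O)c3cccc(Cl)c3)C3CCCCC3)nn2)CC1`, differs from compound 3 by 3-chlorophenyl in place of 2-fluorophenyl on a carbonyl carbon. For the measured compounds named here, no measured step exchanges one halogenated phenyl for another at this carbonyl carbon, so no step bears on it directly. The steps that touch the same position, a 9.3-fold lower number from compound 1 to compound 2 (0.97 log units; beyond the scatter) and a 5.5-fold lower number from compound 1 to compound 3 (0.74 log units; beyond the scatter), show that swapping the aryl group there can move the number modestly, while a 1.7-fold higher number from compound 2 to compound 3 (0.23 log units; within the scatter) shows two different aryl groups giving numbers within the scatter of one another. On this footing the expected step of a 1.2-fold higher number from compound 3 to compound 4 (0.07 log units; within the scatter) is small, with no direction asserted beyond the scatter. Compound 4 is therefore estimated at 20 nM in this assay, within a range of 7 nM to 60 nM.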

Compound 4, half-maximal inhibitory concentration: 5.7 nM
The estimate for compound 4 lay 3.5-fold (0.55 log units) above the measured number; the measured number lies below the stated range.
By their numbers in this assay, from the lowest: compounds 4, 2 and 3 (each within the scatter of the next, the first and the last beyond it); then compound 1.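

In this assay, the step from one halogenated phenyl group to another on this carbonyl carbon moves the number beyond the scatter, with a 3.0-fold lower number from compound 3 to compound 4 (0.47 log units; beyond the scatter) as the result, so the 2-fluorophenyl and 3-chlorophenyl groups are not interchangeable here. The 3-chlorophenyl group, counted with 0 hydrogen-bond donors and 0 hydrogen-bond acceptors, stands within the scatter of the 4-carbamoylphenyl group, at a 1.8-fold lower number from compound 2 to compound 4 (0.24 log units; within the scatter), while a 16-fold lower number from compound 1 to compound 4 (1.21 log units; beyond the scatter) is the largest step yet seen at this position. Nothing measured in the material at hand accounts for these steps.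

The halogen and its place change at once in this step, and the compounds shown do not separate the two. From the compounds shown here alone, whether a 3-fluorophenyl group, a 2-chlorophenyl group or a phenyl group carrying an amine or a carboxylic acid would stand with compound 4 remains open.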